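The compounds below may be only part of what the source reports. "The series", "measured", "known", "first", "only" and "open" are said of these compounds alone.

Measured in a functional assay on T47D cells (Homo sapiens) for antiproliferative activity, read by MTT assay, with a stated time of 72 h; on this read-out higher numbers stand for weaker inhibition and lower numbers for stronger inhibition:
compound 1 `COc1ccc(-n2ccnc2-c2cc(OC)c(OC)c(OC)c2)cc1[N+](=O)[O-]` gives 10000 nM
compound 2 `COc1cc(-c2nccn2-c2cccc([N+](=O)[O-])c2)cc(OC)c1OC` gives 17900 nM
compound 3 `COc1cc(-c2nccn2-c2ccc(F)cc2)cc(OC)c1OC` reports a limit, not a number, > 100000 nM

For the measured compounds named here, only two of these values are true numbers, and they differ by a 1.8-fold higher number from compound 1 to compound 2 (0.25 log units; within the scatter). Going by the values given here, compound 1 therefore sits level with the only other true number in the set.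

Compound 4 `COc1ccc(-n2ccnc2-c2cc(OC)c(OC)c(OC)c2)cc1O` keeps the core of compound 1 and makes one change, (hydroxy in place of nitro on an aromatic carbon), with hydroxy in place of nitro on an aromatic carbon, ortho to a methoxy group.

Among the compounds with values here, no measured step covers this swap directly. The nearest one, the loss of a methoxy group in a 1.8-fold higher number from compound 1 to compound 2 (0.25 log units; within the scatter), concerns a different group and stayed small, so it gives little guidance here. Compound 3 also lacks the nitro group and reports only the limit > 100000 nM. That warns that the group on this ring can matter a great deal, so a step well beyond the scatter is plausible.

The direction is uncertain, but hydroxy brings a hydrogen-bond donor that nitro lacks, so a lower number, meaning stronger inhibition, is the tentative expectation. The estimated change is a 10-fold lower number from compound 1 to compound 4 (1.00 log units; beyond the scatter). For compound 4 the expected value is 1000 nM, with an estimated range from 30 nM to 20000 nM.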

Compound 4, half-maximal inhibitory concentration: 53100 nM
Estimate against measurement, compound 4: 53-fold (1.73 log units) below, outside the stated range (above it).
By their numbers in this assay, from the lowest: compounds 1 and 2 (each within the scatter of the next); then compound 4. At a limit, above all of these: compound 3.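

In this assay, replacing nitro with hydroxy on this aromatic carbon, ortho to a methoxy group, gives a 5.3-fold higher number from compound 1 to compound 4 (0.73 log units; beyond the scatter), and a higher number here means weaker inhibition. For the compounds shown here, this is the only readable step in the set that lies beyond the scatter, unlike the step for hydrogen in place of methoxy, a 1.8-fold higher number from compound 1 to compound 2 (0.25 log units; within the scatter), so the group at this position can visibly shift the read-out, although the size of the shift is modest. Compound 3 reports a limit, not a true number, so steps involving it cannot be read: the limit of > 100000 nM in this assay, at which 1 of the 4 values shown sits.

The compounds shown do not separate the effect of losing nitro from that of gaining hydroxy, so a single swap at one position cannot establish a trend across other groups. Going by these compounds, how an amine, a carboxylic acid or a plain hydrogen on this same carbon would read against compound 1 stays open, as does whether any group here could bring a clearly lower number than compound 1 gives.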